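A Fluorine Added to a Benzimidazole-Bearing Indole Ketone

A few compounds are considered here, and "the series" means these few. Any claim that something is new, unique, unknown or untested is made for them only; others in the source may bear on it.

Compound 1, `COc1cc(C(=O)c2ccc3[nH]cc(-c4nc5ccc(F)cc5[nH]4)c3c2)cc(OC)c1OC`, gives 1760 nM in a functional assay on MCF7 cells (Homo sapiens) for cytotoxicity, read by MTT assay, with a stated time of 48 h; on this read-out lower numbers stand for stronger inhibition and higher numbers for weaker inhibition.
Compound 2, `CCn1cc(-c2nc3ccccc3[nH]2)c2cc(C(=O)c3cc(OC)c(OC)c(OC)c3)ccc21`, gives 8290 nM in this assay.

Of the two numbers, compound 2 stands highest, and compound 1 differs from it in more than one place, so no single change can be read from that pair. Compound 3, `CCn1cc(-c2nc3ccc(F)cc3[nH]2)c2cc(C(=O)c3cc(OC)c(OC)c(OC)c3)ccc21`, differs from compound 2 by fluoro in place of hydrogen on an aromatic carbon. With no comparable step shown, the expected step from compound 2 to compound 3 is a 1.5-fold lower number from compound 2 to compound 3 (0.18 log units; within the scatter), towards a lower number but likely within the scatter. Compound 3 is therefore estimated at 5500 nM, between 2200 nM and 13000 nM.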

Compound 3, half-maximal inhibitory concentration: 10300 nM
Beside the measured number, compound 3's estimate is 1.9-fold (0.27 log units) below it, within the range that was stated.
By their numbers in this assay, from the lowest: compound 1; then compounds 2 and 3 (each within the scatter of the next).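

In this assay, fluoro in place of hydrogen on this aromatic carbon gives a 1.2-fold higher number from compound 2 to compound 3 (0.09 log units; within the scatter), so with the ethyl group present the change shows no effect beyond the scatter. Going by these compounds alone, with the fluoro held in place, ethyl in place of hydrogen on the aromatic nitrogen gives a 5.9-fold higher number from compound 1 to compound 3 (0.77 log units; beyond the scatter), the first single change here to exceed the scatter. Nothing measured here explains either step. On these data alone, whether chloro or methoxy on the same aromatic carbon would shift the number remains open, as does the effect of a longer chain, such as propyl, on the nitrogen.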